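A few compounds are considered here, and "the series" means these few. Any claim that something is new, unique, unknown or untested is made for them only; others in the source may bear on it.

Three measured compounds share one skeleton and differ only in configuration. In a physicochemical assay for solubility, in phosphate buffer (a higher number here means a more soluble compound, a lower number a less soluble compound), compound 1 `C[C@@H]1CN([C@@H](C)CO)C(=O)c2cccc(NC(=O)c3ccncc3)c2O[C@@H]1CN(C)Cc1ccc(Oc2ccccc2)cc1` gives 87000 nM, compound 2 `C[C@H]1CN([C@@H](C)CO)C(=O)c2cccc(NC(=O)c3ccncc3)c2O[C@H]1CN(C)Cc1ccc(Oc2ccccc2)cc1` gives 93000 nM, and compound 3 `C[C@H]1CN([C@@H](C)CO)C(=O)c2cccc(NC(=O)c3ccncc3)c2O[C@@H]1CN(C)Cc1ccc(Oc2ccccc2)cc1` gives 1000 nM. Compound 3 stands lowest of the three: the gap to compound 1 and to compound 2 is beyond the scatter in both cases, and it is large.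

Compound 4 `C[C@@H]1CN([C@H](C)CO)C(=O)c2cccc(NC(=O)c3ccncc3)c2O[C@@H]1CN(C)Cc1ccc(Oc2ccccc2)cc1` has not yet been measured in this assay. It differs from compound 3 as follows: the two compounds have the same atoms and bonds and differ only in configuration as drawn: 2 of 3 stereo elements differ; a stereocentre at a saturated ring carbon is drawn S in compound 3 and R in compound 4; a stereocentre at a saturated chain carbon is drawn S in compound 3 and R in compound 4.

The measured steps that bear on this change are those involving the ring stereocentre. In this assay there was an 87-fold lower number from compound 1 to compound 3 (1.94 log units; beyond the scatter) and a 93-fold lower number from compound 2 to compound 3 (1.97 log units; beyond the scatter), each the inversion of a single ring stereocentre the fact that compounds 1 and 3 differ only in the configuration as drawn (the fact that compounds 2 and 3 differ only in the configuration as drawn). By contrast there was a 1.1-fold higher number from compound 1 to compound 2 (0.03 log units; within the scatter), where two ring stereocentres were inverted together (the fact that compounds 1 and 2 differ only in the configuration as drawn). Within the data shown here, the step from compound 3 to compound 4 undoes the ring inversion that separated compound 3 from compound 1, while also inverting the chain stereocentre, for which no measured step exists. The account therefore expects a large rise in this assay, estimated as a 40-fold higher number from compound 3 to compound 4 (1.60 log units; beyond the scatter), with the chain inversion adding uncertainty. Compound 4 is expected to give about 40000 nM in this assay, within a range of 5000 nM to 150000 nM.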

Compound 4, solubility: 86000 nM
For compound 4 the middle estimate is 2.2-fold (0.33 log units) below the measured one; low and high end bracket the measured number.
By their numbers in this assay, from the lowest: compound 3; then compounds 4, 1 and 2 (each within the scatter of the next).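

In this assay the chain stereocentre now has a measured step of its own (a 1.0-fold lower number from compound 1 to compound 4 (0.01 log units; within the scatter)), and inverting that saturated chain carbon alone leaves the two numbers within the scatter of each other. Compound 4 is the mirror image of compound 2, and that pair also lies within the scatter (a 1.1-fold lower number from compound 2 to compound 4 (0.03 log units; within the scatter)), so compounds 1, 2 and 4 form one group in this assay, with compound 3 the only one of the four that goes against it. The large gap that sets compound 3 apart holds here too (an 86-fold higher number from compound 3 to compound 4 (1.93 log units; beyond the scatter)), and it arises from configuration alone, because nothing else separates the two: the fact that compounds 3 and 4 differ only in the configuration as drawn.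

Among these compounds, whether the chain stereocentre would matter just as little on the ring configuration of compound 3 stays open, since all that is known of that carbon comes from the single pair of compound 1 and compound 4. Also open, as far as these compounds go, is whether the large gap for this one configuration would persist if the hydroxyl group on the chain gave way to an amine or a carboxylic acid.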